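A few compounds are considered here, and "the series" means these few. Any claim that something is new, unique, unknown or untested is made for them only; others in the source may bear on it.

Of the compounds shown here, three have been measured in a functional assay (B cells) with Mus musculus as the target; a lower number here means that less compound is needed, a higher number that more compound is needed for the effect. Compound 1, `[N-]=[N+]=NCC(O)Cn1c(=O)n(C2OC(CO)[C@@H](O)[C@H]2O)c2nc(N)nc(O)c21`, gives 39 uM in this assay, the highest of the three numbers. Compound 2, `C=CCn1c(=O)n(C2OC(CO[Si](c3ccccc3)(c3ccccc3)C(C)(C)C)[C@@H](O)[C@H]2O)c2nc(N)nc(O)c21`, gives 18 uM, and compound 3, `C=CCn1c(=S)n(COCCO)c2nc(N)nc(O)c21`, gives 14 uM; both gaps to compound 1 lie beyond the usual scatter, so compound 1 sits at the weak end of what has been measured. No two of the measured compounds differ in a single place, so no single-point step can be read off.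

Compound 4, `Nc1nc(O)c2c(n1)n(C1OC(CO)[C@@H](O)[C@H]1O)c(=O)n2Cc1ccccc1`, has not yet been measured. It differs from compound 1 as follows: phenyl in place of 2-azido-1-hydroxyethyl on a saturated chain carbon bound to an aromatic nitrogen. For the measured compounds named here, since no measured pair isolates this change, its size can only be guessed from the spread already seen. Compound 4 is expected to give 20 uM in this assay, within 6 uM to 60 uM. This estimate corresponds to a 2.0-fold lower number from compound 1 to compound 4 (0.29 log units; within the scatter), a modest shift that may or may not clear the scatter.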

Compound 4, concentration for half-maximal effect: 6 uM
Estimate against measurement, compound 4: 3.3-fold (0.52 log units) above; the range from low to high includes it.
By their numbers in this assay, from the lowest: compound 4; then compounds 3 and 2 (each within the scatter of the next); then compound 1.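

Phenyl in place of 2-azido-1-hydroxyethyl on a saturated chain carbon bound to an aromatic nitrogen gives the first single-place step of this series in this assay: a 6.5-fold lower number from compound 1 to compound 4 (0.81 log units; beyond the scatter). The number at this position therefore depends on the group it carries, and the benzyl group, with no hydrogen-bond donors or acceptors, is compatible with a lower number than 3-azido-2-hydroxypropyl. No measurement offered here explains the step.

This one step exchanges the azide, the hydroxyl and the ring together, so the compounds shown do not tell which of these parts carries the difference. Going by these compounds, whether a plain propyl chain, an azidopropyl chain or a cyclohexylmethyl group would keep the lower number at this place remains open.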